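The source may report more compounds than this note shows. Statements on the series, on what has been measured and on what is new or still open speak of the compounds shown alone.

Compound 3 `O=C(Nc1cccc(F)c1)C(Cl)Cl` has no number in a functional assay on A549 cells (Homo sapiens) for antiproliferative activity, read by MTT assay, with a stated time of 72 h; a higher number here means a weaker inhibitor, a lower number a stronger inhibitor: for compound 3 the result is given only as "not determined" (no result reported), so it stands nowhere on the scale that the other compounds define. The step to compound 4 `O=C(Nc1cccc(SC(F)(F)F)c1)C(Cl)Cl` is a change on the aromatic ring: (trifluoromethyl)sulfanyl in place of fluoro on an aromatic carbon

For the measured compounds named here, the only measured step in this set is the one from compound 1 `O=C(Nc1ccccc1Br)C(Cl)Cl` to compound 2 `O=C(Nc1ccccc1NC(=O)C(Cl)Cl)C(Cl)Cl`, where in this assay compound 1 gives 37000 nM and compound 2 gives 131000 nM, a change of a 3.5-fold higher number from compound 1 to compound 2 (0.55 log units; beyond the scatter). That step concerns a different group on a different ring position and does not bear directly on the exchange of fluoro for (trifluoromethyl)sulfanyl. What the two measured compounds show is that the shared core sits in the weak range of this assay, so for compound 4 a number of similar order is expected rather than a large shift in either direction. Compound 4 is therefore estimated at 30000 nM, with a range from 8000 nM to 150000 nM.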

Compound 4, half-maximal inhibitory concentration: 14100 nM
Beside the measured number, compound 4's estimate is 2.1-fold (0.33 log units) above it, and the stated range covers the measured number.
By their numbers in this assay, from the lowest: compound 4; then compound 1; then compound 2.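

With compound 3 carrying no number in this assay, the step from compound 3 to compound 4 cannot be read. As far as these compounds go, what exchanging fluoro for (trifluoromethyl)sulfanyl does to the inhibitory concentration therefore stays open, and no supporting evidence bears on this result.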